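This account rests on a few compounds, and the source may have more. Where it says the series, first, only, none or still open, it means among the compounds named here.

Three compounds of this series carry measurements in a toxicity assay on MDCK cells (Canis lupus familiaris) for cytotoxicity, read by crystal violet staining, with a stated time of 48 h; on this read-out lower numbers stand for higher toxicity in this test and higher numbers for lower toxicity in this test. Compound 1 `Cc1ccc2cc(CN(Cc3ccc(F)cc3)Cc3ccc(C(F)(F)F)cc3)c(=O)[nH]c2c1` gives > 33000 nM in this assay, which is a limit of the assay and not a number. Compound 2 `Cc1ccc2cc(CNCc3ccc(F)cc3)c(=O)[nH]c2c1` likewise gives > 33000 nM in this assay, again only a limit. Among the measured compounds shown here, the single change between the two, a step that the two limits leave unreadable from compound 1 to compound 2, therefore cannot be sized. Compound 3 `Cc1ccc2[nH]c(=O)c(CN(Cc3ccc(OCC(=O)OC(C)(C)C)cc3)Cc3ccc(C(C)(C)C)cc3)cc2c1` gives > 10000 nM in this assay, also a limit and not a number. Compound 3 thus stands with the other two: the limit of > 10000 nM in this assay, at which 1 of the 3 values shown sits, and the limit of > 33000 nM in this assay, at which 2 of the 3 values shown sit, together cover every value shown, and no measured number exists in this assay.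

Compound 4 `Cc1ccc2[nH]c(=O)c(CN(Cc3ccc(C#N)cc3)Cc3ccc(C(C)(C)C)cc3)cc2c1` differs from compound 3 in one place: cyano in place of (tert-butoxycarbonyl)methoxy on an aromatic carbon. For the measured compounds named here, no measured step touches this change, and the only step recorded is itself unreadable, so nothing in hand points in either direction. The step from compound 3 to compound 4 is expected to be a step that the limit leaves unreadable from compound 3 to compound 4. For compound 4 the value in this assay is estimated at 33000 nM, within 10000 nM to 100000 nM, most likely again reported only as a limit.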

Compound 4, half-maximal cytotoxic concentration: > 5000 nM
Compound 4 ended at the assay's limit; the forecaster's own chance of this, stated with the estimate: 85%; the middle value is on the limit's open side.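

In this assay compound 3 and compound 4 both stand only as limits of the assay, and the step between them cannot be read. The compounds shown leave open at what concentration any of them turns cytotoxic, and whether cyano in place of (tert-butoxycarbonyl)methoxy changes that concentration at all.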